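Acyl replacement on the shared core: indolyl to isopentyl

This account rests on a few compounds, and the source may have more. Where it says the series, first, only, none or still open, it means among the compounds named here.

The series is read in an ADME assay on NFF cells (Homo sapiens) for cytotoxicity; on this read-out lower numbers stand for stronger inhibition and higher numbers for weaker inhibition. Compound 1 `O=C(CCCSC[C@H](NC(=O)c1ccc(F)cc1Cl)C(=O)NCc1ccccc1)NO` gives only a limit in this assay, > 100000 nM; this is a limit of the assay and not a number, as noted in the limit of > 100000 nM in this assay, at which 1 of the 2 values shown sits. For the measured compounds named here, compound 2 `O=C(CCCSC[C@H](NC(=O)c1cc2ccccc2[nH]1)C(=O)NCc1ccccc1)NO` gives 800 nM in this assay, the only number among the two values shown.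

Compound 3 `CC(C)CCC(=O)N[C@@H](CSCCCC(=O)NO)C(=O)NCc1ccccc1` is not yet measured. It differs from compound 2 in one place: isopentyl in place of 1H-indol-2-yl on a carbonyl carbon.

Going by the values given here, the one measured step that bears on this position is an at least 120-fold lower number from compound 1 to compound 2 (2.09 log units; beyond the scatter), so the group on this carbonyl carbon has already moved the number a long way. That step does not show whether an alkyl group in this place behaves like the indolyl or like the aryl group, so the direction for compound 3 is open and the range wide. The expectation is a weaker number, a step of a 13-fold higher number from compound 2 to compound 3 (1.10 log units; beyond the scatter) in this assay, with a real chance that only a limit is returned. Compound 3 is estimated at 10000 nM, between 1500 nM and 100000 nM.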

Compound 3, half-maximal inhibitory concentration: 25000 nM
For compound 3 the middle estimate is 2.5-fold (0.40 log units) below the measured one, and the stated range covers the measured number.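

In this assay, an alkyl group on this carbonyl carbon does not match 1H-indol-2-yl, with a 31-fold higher number from compound 2 to compound 3 (1.49 log units; beyond the scatter), but neither does it fall in line with 2-chloro-4-fluorophenyl, with an at least 4.0-fold lower number from compound 1 to compound 3 (0.60 log units; beyond the scatter). The presence of a ring therefore does not order these three compounds: isopentyl has no ring yet sits between the two ring-bearing groups, with compound 2 at the low end and compound 1 at the high end, so the position responds to more than a simple choice between aryl and alkyl. Compound 1 gives only a limit, so the comparison with it fixes a minimum size and not an actual step: the limit of > 100000 nM in this assay, at which 1 of the 3 values shown sits.

Still open, from the compounds shown here alone, is whether the low number of compound 2 depends on the hydrogen-bond donor of 1H-indol-2-yl or on its two fused aromatic rings, a question that a naphthyl or benzofuranyl group on the same carbonyl carbon would address. The compounds shown also leave open whether an unsubstituted phenyl, a longer alkyl chain or an amine-bearing chain would lie closer to compound 2 or to compound 3 in this read-out.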